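Swapping the Substituted Anilino Group for Phenyl

A few compounds are considered here, and "the series" means these few. Any claim that something is new, unique, unknown or untested is made for them only; others in the source may bear on it.

Measured so far:
- compound 1 `COc1cc(-c2nn(-c3cccc(NC(=O)Nc4cccc(C(F)(F)F)c4)c3)cc2-c2ccncc2)ccc1Cl` gives 2310 nM in a functional assay on UACC-257 cells (Homo sapiens) for inhibition, read by sulforhodamine B assay, with a stated time of 48 h; a lower number here means a stronger inhibitor of growth, a higher number a weaker inhibitor of growth
- compound 2 `COc1cc(-c2nn(-c3cccc(NC(=O)Nc4ccc(Cl)c(C(F)(F)F)c4)c3)cc2-c2ccncc2)ccc1Cl` gives 6030 nM in this assay

Among the compounds with values here, compound 2 has the higher number of the two, so it is the weaker growth inhibitor; the one measured step, a 2.6-fold higher number from compound 1 to compound 2 (0.42 log units; beyond the scatter), is modest. Compound 3 `COc1cc(-c2nn(-c3cccc(NC(=O)c4ccccc4)c3)cc2-c2ccncc2)ccc1Cl` is the unmeasured neighbour of compound 2: phenyl in place of (4-chloro-3-(trifluoromethyl)phenyl)amino on a carbonyl carbon. Within the data shown here, no measured step touches the carbonyl carbon, so the chloro step gives no direct guide. Since the change removes far more than any measured step did, compound 3 is expected to be a weaker inhibitor, with an expected step of a 2.0-fold higher number from compound 2 to compound 3 (0.30 log units; within the scatter). The estimate for compound 3 is 12000 nM, in a range from 3500 nM to 40000 nM.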

Compound 3, concentration for total growth inhibition: > 100000 nM
Compound 3 ended at the assay's limit (the forecaster's own chance of this, stated with the estimate: 15%); middle value at least 8.3-fold (0.92 log units) away from the limit.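

Phenyl in place of (4-chloro-3-(trifluoromethyl)phenyl)amino on the carbonyl carbon gives an at least 16-fold higher number from compound 2 to compound 3 (1.21 log units; beyond the scatter), and phenyl in place of (3-(trifluoromethyl)phenyl)amino gives an at least 43-fold higher number from compound 1 to compound 3 (1.63 log units; beyond the scatter). Compound 3 stands at a limit of this assay, not at a number: the limit of > 100000 nM in this assay, at which 1 of the 3 values shown sits. Both steps are large, so the group on this carbonyl carbon matters much more than the modest chloro step suggested. Still open, on these data alone, is whether the amino nitrogen or the ring's chloro and trifluoromethyl groups matter most. A plain phenylamino group on this carbon would help separate the two.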